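Triazole aryl swap: trichlorophenyl analogue of the spiro series

The source may report more compounds than this note shows. Statements on the series, on what has been measured and on what is new or still open speak of the compounds shown alone.

Compound 1 `COc1ccc(-n2nncc2CN2C(=O)C3(C(C#N)=C(N)Oc4c(N)cc5nc6ccccc6nc5c43)c3ccccc32)cc1` gives only a limit of the assay, not a number, in an ADME assay on HUVEC cells (Homo sapiens) for antiproliferative activity, read by MTT assay, with a stated time of 48 h (on this read-out higher numbers stand for weaker inhibition and lower numbers for stronger inhibition), reported as > 50000 nM. Compound 2 `COc1ccc(OC)c(-n2nncc2CN2C(=O)C3(C(C#N)=C(N)Oc4c(N)cc5nc6ccccc6nc5c43)c3ccccc32)c1` likewise reaches only a limit in this assay, reading > 50000 nM. The change between them, 2,5-dimethoxyphenyl in place of 4-methoxyphenyl on an aromatic nitrogen, is a step that the two limits leave unreadable from compound 1 to compound 2; both values sit at the limit of > 50000 nM in this assay, at which 2 of the 2 values shown sit. Compound 3 `N#CC1=C(N)Oc2c(N)cc3nc4ccccc4nc3c2C12C(=O)N(Cc1cnnn1-c1c(Cl)cc(Cl)cc1Cl)c1ccccc12` carries the next change at the same aromatic nitrogen: 2,4,6-trichlorophenyl in place of 2,5-dimethoxyphenyl on an aromatic nitrogen. Among the measured compounds shown here, the single measured step in this assay bears on it and is unreadable, so no size can be read for the change from compound 2 to compound 3; with both known values at the limit, compound 3 is expected to remain at the limit as well. The step implied by this expectation is a step that the limit leaves unreadable from compound 2 to compound 3, nothing beyond the scatter. Compound 3 is accordingly estimated at 60000 nM, with a range from 20000 nM to 200000 nM.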

Compound 3, half-maximal inhibitory concentration: 18300 nM
The estimate for compound 3 lay 3.3-fold (0.52 log units) above the measured number, and the stated range ends above it.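

Working notes: in this assay, the group on the aromatic nitrogen of the five-membered ring can move the read-out, since 2,4,6-trichlorophenyl gives an at least 2.7-fold lower number from compound 2 to compound 3 (0.43 log units; beyond the scatter) and an at least 2.7-fold lower number from compound 1 to compound 3 (0.43 log units; beyond the scatter). Both steps start from a limit, so each gives only a lower bound on the size of the change, and the step between the two methoxy-bearing compounds cannot be read. Compound 3 is the only compound here with a number rather than a limit of the assay, and the other two share that limit: the limit of > 50000 nM in this assay, at which 2 of the 3 values shown sit.

Whether the chlorine atoms themselves or their places on the phenyl ring account for the step stays open, since compound 3 differs from compound 2 in both. Also open, from the compounds shown here alone, is how an amine, a carboxylic acid or a longer chain at this nitrogen would read.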